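The source may report more compounds than this note shows. Statements on the series, on what has been measured and on what is new or still open speak of the compounds shown alone.

Going by the values given here, in a functional assay on A2780 cells (Homo sapiens) for antiproliferative activity, read by resazurin assay, with a stated time of 72 h (a higher number here means a weaker inhibitor, a lower number a stronger inhibitor), compound 1 (`Cc1cccc(Cc2n[nH]c3cc(O)c(C(=O)N(C)Cc4cccc(F)c4)cc23)c1`) gives 440 nM and compound 2 (`COc1ccc(CN(C)C(=O)c2cc3c(Cc4cccc(C)c4)n[nH]c3cc2O)cc1`) gives 540 nM so compound 2 stands level with its only neighbour, within the scatter. Compound 3 (`Cc1cccc(Cc2n[nH]c3cc(O)c(C(=O)N(C)Cc4ccc(Cl)c(F)c4)cc23)c1`) carries 4-chloro-3-fluorophenyl in place of 4-methoxyphenyl on a saturated chain carbon bound to an amide-type nitrogen. Among the compounds with values here, the one measured step at this place (a 1.2-fold higher number from compound 1 to compound 2 (0.09 log units; within the scatter)) stayed within the scatter, so no step beyond the scatter is expected in this assay here. The expected step (a 1.4-fold lower number from compound 2 to compound 3 (0.15 log units; within the scatter)) is small. For compound 3 the estimated value is 380 nM with an expected range (160 nM to 900 nM).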

Compound 3, half-maximal inhibitory concentration: 930 nM
The estimate for compound 3 lay 2.4-fold (0.39 log units) below the measured number, and the stated range ends below it.
By their numbers in this assay, from the lowest: compounds 1, 2 and 3 (each within the scatter of the next, the first and the last beyond it).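

Chloro in place of hydrogen on an aromatic carbon gives the first step beyond the scatter at this place, on a saturated chain carbon bound to an amide-type nitrogen, though a modest one (a 2.1-fold higher number from compound 1 to compound 3 (0.33 log units; beyond the scatter)). Against 4-methoxyphenyl, the 4-chloro-3-fluorophenyl group stays within the scatter (a 1.7-fold higher number from compound 2 to compound 3 (0.24 log units; within the scatter)). Nothing available accounts for either step.

Still open, on these data alone, is how 4-chlorophenyl, carrying no fluorine, would compare. Also open, as far as these compounds go, is whether an amine or a carboxylic acid on this ring, or a longer chain in place of the benzyl carbon, would shift the number.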